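Growth inhibition notes on two measured compounds and one pending

The source may hold more compounds than are shown below. What is called first, only, known or untested is meant among the compounds shown, and "the series" means these compounds.

Measured in a functional assay on MCF7 cells (Homo sapiens) for inhibition, read by MTT assay, with a stated time of 72 h, tested at 10 ug/mL; a higher number here means more inhibition of growth at the concentration tested, a lower number less inhibition of growth:
- compound 1 `C=C1[C@H](OCC(C)C)C[C@@H](OC(=O)c2cccnc2)C(C)(C)/C=C/[C@@H](C)C(=O)[C@@]2(OC(C)=O)C[C@H](C)[C@H](OC(C)=O)[C@@H]2[C@H]1OC(C)=O`: 18.5%
- compound 2 `C=C1[C@H](OCC(C)C)C[C@@H](OC(=O)c2cccnc2)C(C)(C)/C=C/[C@@H](C)C(=O)[C@@]2(OC(C)=O)C[C@@](C)(OC(C)=O)[C@H](OC(C)=O)[C@@H]2[C@H]1OC(C)=O`: 3.6%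

Compound 2 gives 3.6%, the lower of the two numbers, and compound 1 stands higher, beyond the scatter. Compound 3 `C=C1[C@H](OC(C)=O)C[C@@H](OC(=O)c2cccnc2)C(C)(C)/C=C/[C@@H](C)C(=O)[C@@]2(OC(C)=O)C[C@@](C)(OC(C)=O)[C@H](OC(C)=O)[C@@H]2[C@H]1OC(C)=O` differs from compound 2 as follows: acetyl in place of isobutyl on an oxygen on a saturated carbon. This places acetyl in place of isobutyl on an oxygen on a saturated carbon. Among the compounds with values here, no measured pair covers this change, so only a small rise in this assay, or none beyond the scatter, is expected. The estimated step is a number 4.4 percentage points higher from compound 2 to compound 3 (within the scatter). For compound 3 the expected value is 8%, with an estimated range of 0% to 22%.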

Compound 3, percent growth inhibition at one concentration: 20.3%
Estimate against measurement, compound 3: 12.3 percentage points below; measured number inside the range.
By their numbers in this assay, from the lowest: compound 2; then compounds 1 and 3 (each within the scatter of the next).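

Acetyl in place of isobutyl on an oxygen on a saturated carbon gives the first step read at this position (a number 16.7 percentage points higher from compound 2 to compound 3 (beyond the scatter)) in this assay on the core of compound 2. The position therefore responds to the group it carries, with isobutoxy to acetoxy moving the number upward on this core. Nothing measured here bears on the reason for this step.

Going by these compounds, whether the same change gives a similar step on the core of compound 1 remains open. Also open, on these data alone, is how a longer chain or an amine would read on this oxygen.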